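The source may hold more compounds than are shown below. What is called first, only, known or untested is meant among the compounds shown, and "the series" means these compounds.

In an assay on Sf9 cells for inhibition of serine/threonine-protein kinase 4 (Homo sapiens), read by luminescence and ADP-Glo, with a stated time of 1 h, in the presence of a further agent that is not named here (on this read-out lower numbers stand for stronger inhibition and higher numbers for weaker inhibition), compound 1 `CN1C(=O)C(C2CC2)N(C)c2nc(Nc3ccc(S(N)(=O)=O)cc3)ncc21` gives 136 nM. Among the three compounds measured so far it holds the second highest number: compound 2 `CC(C)C1C(=O)N(C)c2cnc(Nc3ccc(S(N)(=O)=O)cc3)nc2N1C` gives 254 nM, and compound 3 `CN1C(=O)C(c2ccccc2Br)N(C)c2nc(Nc3ccc(S(N)(=O)=O)cc3)ncc21` gives 57 nM. The move a 1.9-fold higher number from compound 1 to compound 2 (0.27 log units; within the scatter) stays within the scatter, whereas a 2.4-fold lower number from compound 1 to compound 3 (0.38 log units; beyond the scatter) and a 4.5-fold lower number from compound 2 to compound 3 (0.65 log units; beyond the scatter) are both modest but real shifts toward stronger inhibition.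

Compound 4 `Cc1c(F)cccc1C1C(=O)N(C)c2cnc(Nc3ccc(S(N)(=O)=O)cc3)nc2N1C` differs from compound 1 in one place: 3-fluoro-2-methylphenyl in place of cyclopropyl on a saturated ring carbon. The measured steps that bear on this are the two leading into compound 3, since each of them likewise placed a six-membered aromatic ring on that saturated ring carbon in place of a small saturated group, and each gave a lower number. Going by the values given here, on that basis a modest step downward is expected for compound 4, of roughly the size seen from compound 1 to compound 3, though only two such steps exist and the aromatic ring entering here carries a different set of substituents, so the expectation is held loosely. The step expected from compound 1 to compound 4 is a 2.1-fold lower number from compound 1 to compound 4 (0.32 log units; beyond the scatter). Compound 4 is therefore estimated at 65 nM, with a plausible range from 30 nM to 150 nM.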

Compound 4, half-maximal inhibitory concentration: 419 nM
Compound 4: the middle estimate sits 6.4-fold (0.81 log units) below what was measured; the measured number lies above the stated range.
By their numbers in this assay, from the lowest: compound 3; then compounds 1, 2 and 4 (each within the scatter of the next, the first and the last beyond it).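

An aromatic ring on this saturated ring carbon does not by itself give a lower number in this assay: placing 3-fluoro-2-methylphenyl where cyclopropyl stood gives a 3.1-fold higher number from compound 1 to compound 4 (0.49 log units; beyond the scatter), which runs opposite to the step that 2-bromophenyl gave in the same place. What the ring carries therefore matters a good deal, as the exchange between the two aromatic groups gives a 7.4-fold higher number from compound 3 to compound 4 (0.87 log units; beyond the scatter), while the comparison with the small saturated group isopropyl gives a 1.6-fold higher number from compound 2 to compound 4 (0.22 log units; within the scatter), so compound 4 cannot be told apart from compound 2 on this read-out. No measurement at hand explains why these two substituted aromatic rings behave so differently.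

The two rings differ in bromine, fluorine and methyl all at once, so these compounds cannot show which of these groups accounts for the gap, and a plain phenyl ring or a ring carrying only a methyl group would be needed to separate them. Also open, going by these compounds, is how this ring carbon would respond to a group of a different kind, such as an amine or a carboxylic acid.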